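Naphthyl sulfonamide on the octadecyl amide chain

A few compounds are considered here, and "the series" means these few. Any claim that something is new, unique, unknown or untested is made for them only; others in the source may bear on it.

Compound 3 `CCCCCCCCCCCCCCCCCCNC(=O)[C@@H](NS(=O)(=O)c1cccs1)[C@@H](C)O` sits at the floor of the numbers seen: in a functional assay on MCF7 cells (Homo sapiens) for cytotoxicity, read by MTT assay, with a stated time of 48 h (a higher number here means a weaker inhibitor, a lower number a stronger inhibitor), compound 3 gives only the limit > 200000 nM. Compound 2 `CCCCCCCCCCCCCCCCCCNC(=O)[C@@H](NS(=O)(=O)c1ccc(C)cc1)[C@@H](C)O` gives 60100 nM in this assay. Within the data shown here, the step of an at least 3.3-fold higher number from compound 2 to compound 3 (0.52 log units; beyond the scatter) is the one measured step that touches the sulfonyl substituent; it rests on the limit of compound 3 (the limit of > 200000 nM in this assay, at which 1 of the 3 values shown sits), so its full size is open. Among the measured compounds shown here, compound 1 `CCCCCCCCCCCCCCNC(=O)[C@@H](NS(=O)(=O)c1ccc2ccccc2c1)[C@@H](C)O`, with a tetradecyl chain, gives 12200 nM in this assay; no single-change step links it to the others. Compound 4 `CCCCCCCCCCCCCCCCCCNC(=O)[C@@H](NS(=O)(=O)c1ccc2ccccc2c1)[C@@H](C)O` carries the change (naphthalen-2-yl in place of thiophen-2-yl on a sulfonyl sulfur). Compound 4 removes the thiophene whose entry gave the weaker number, so the expected step of an at least 6.6-fold lower number from compound 3 to compound 4 (0.82 log units; beyond the scatter) runs toward a lower number. Compound 4 is estimated at 30000 nM, between 8000 nM and 150000 nM.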

Compound 4, half-maximal inhibitory concentration: 27800 nM
The estimate for compound 4 lay 1.1-fold (0.03 log units) above the measured number; the measured number falls inside the stated range.
By their numbers in this assay, from the lowest: compound 1; then compound 4; then compound 2. At a limit, above all of these: compound 3.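

Naphthalen-2-yl on the sulfonyl sulfur reads lower than either of the other two groups on the octadecyl chain in this assay, with a 2.2-fold lower number from compound 2 to compound 4 (0.33 log units; beyond the scatter) and an at least 7.1-fold lower number from compound 3 to compound 4 (0.85 log units; beyond the scatter). With naphthalen-2-yl held constant, chain length now has a measured step, butyl in place of hydrogen giving a 2.3-fold higher number from compound 1 to compound 4 (0.36 log units; beyond the scatter). The full size of the step from the thiophene remains open, as it rests on a limit: the limit of > 200000 nM in this assay, at which 1 of the 4 values shown sits.

From the compounds shown here alone, whether the order of the sulfonyl groups holds on the tetradecyl chain remains open. Going by these compounds, how an amine on the naphthalen-2-yl ring or a chain longer than octadecyl would read also remains open.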